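Chain length and tolerated concentration in HEL cells

A few compounds are considered here, and "the series" means these few. Any claim that something is new, unique, unknown or untested is made for them only; others in the source may bear on it.

Compound 1, `CCCCCCc1cc2cn(C3CCC(CO)O3)c(=O)nc2o1`, in a functional assay on HEL cells (Homo sapiens) (a lower number here means that less compound is tolerated, a higher number that more compound is tolerated), gives > 143000 nM, which is a limit of the assay and not a number.
Compound 2, `CCCCCCCCc1cc2cn(C3CCC(CO)O3)c(=O)nc2o1`, gives > 112000 nM, again a limit.
Compound 3, `CCCCCCCCCc1cc2cn(C3CCC(CO)O3)c(=O)nc2o1`, gives > 200000 nM, also a limit.

Compound 3 therefore stands only at a limit, as do the two others. The steps a step that the two limits leave unreadable from compound 1 to compound 2, a step that the two limits leave unreadable from compound 1 to compound 3 and a step that the two limits leave unreadable from compound 2 to compound 3 are all unreadable, since (the limit of > 112000 nM in this assay, at which 1 of the 3 values shown sits), the limit of > 143000 nM in this assay, at which 1 of the 3 values shown sits, and the limit of > 200000 nM in this assay, at which 1 of the 3 values shown sits, give no numbers. Compound 4, `CCCCCCCCCCc1cc2cn(C3CCC(CO)O3)c(=O)nc2o1`, carries methyl in place of hydrogen on a saturated chain carbon, nine bonds along the chain from an aromatic carbon. With every neighbouring step unreadable, the expected step of a number no higher from compound 3 to compound 4 (the limit leaves the size open) is none beyond the scatter, and compound 4 is estimated at 200000 nM, between 100000 nM and 400000 nM, most likely reported again as a limit.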

Compound 4, half-maximal cytotoxic concentration: > 200000 nM
Compound 4 gave a limit, no number; the forecaster's own chance of this, stated with the estimate: 85%; the middle value sits exactly at the limit.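

Going by these compounds alone, compound 4 gives only a limit and no number, as do compound 1, compound 2 and compound 3, so no step to compound 4 can be read. From the compounds shown here alone, the cytotoxic concentration in this assay stays open for all four compounds, and so does any effect of chain length.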